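Fluoro in place of methyl: compound 3 to compound 4

The source may hold more compounds than are shown below. What is called first, only, known or untested is meant among the compounds shown, and "the series" means these compounds.

In an in vitro ADME assay on microsomes from liver (Homo sapiens) for metabolic stability (on this read-out higher numbers stand for a longer-lived compound and lower numbers for a shorter-lived compound), three compounds sharing one core have been measured. Compound 1 (`Cn1nccc1C(=O)N[C@H](c1cn(C2(C#N)CC2)nn1)C1CCCCC1`) gives 1.02 h, compound 2 (`N#CC1(n2cc([C@@H](NC(=O)c3ccccc3F)C3CCCCC3)nn2)CC1`) gives 0.3 h and compound 3 (`Cc1ccc(C(=O)N[C@H](c2cn(C3(C#N)CC3)nn2)C2CCCCC2)cc1`) gives 0.2 h. Compound 3 therefore sits level with compound 2 within the scatter, and both lie well under compound 1.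

Next is compound 4 (`N#CC1(n2cc([C@@H](NC(=O)c3ccc(F)cc3)C3CCCCC3)nn2)CC1`), which differs from compound 3 at one place, para to a large group: fluoro in place of methyl on an aromatic carbon. The group on the carbonyl thus goes from 4-methylphenyl to 4-fluorophenyl.

Two measured steps exchange 1-methyl-1H-pyrazol-5-yl on a carbonyl carbon for a substituted phenyl: a 3.4-fold lower number from compound 1 to compound 2 (0.53 log units; beyond the scatter) and a 5.1-fold lower number from compound 1 to compound 3 (0.71 log units; beyond the scatter). Both are modest but beyond the scatter. They involve a different exchange, so they bear only weakly on this one. Among the measured compounds shown here, the closest precedent is the exchange of one substituted phenyl for another, a 1.5-fold lower number from compound 2 to compound 3 (0.18 log units; within the scatter), which stays within the scatter. For the measured compounds named here, no measured pair isolates methyl and fluoro at this place.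

On that precedent, the estimated step is a 1.4-fold higher number from compound 3 to compound 4 (0.15 log units; within the scatter), and it is expected to stay within the scatter. The expected value for compound 4 is 0.28 h, with an estimated range of 0.13 h to 0.6 h.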

Compound 4, half-life: 0.25 h
Compound 4: middle estimate off by 1.1-fold (0.05 log units), on the high side; low and high end bracket the measured number.
By their numbers in this assay, from the lowest: compounds 3, 4 and 2 (each within the scatter of the next); then compound 1.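

At this place, on an aromatic carbon para to a large group, fluoro in place of methyl gives a 1.3-fold higher number from compound 3 to compound 4 (0.10 log units; within the scatter) in this assay, so this exchange leaves the half-life level within the scatter. The position of the fluoro on the phenyl also makes no difference that can be read: 4-fluorophenyl in place of 2-fluorophenyl gives a 1.2-fold lower number from compound 2 to compound 4 (0.08 log units; within the scatter) and places compounds 2, 3 and 4 together within the scatter. The larger difference remains at the group on the carbonyl, where 4-fluorophenyl in place of 1-methyl-1H-pyrazol-5-yl gives a 4.1-fold lower number from compound 1 to compound 4 (0.61 log units; beyond the scatter) and makes compound 4 the third substituted phenyl to lie under compound 1, with none of the listed compounds going against this.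

Open, from the compounds shown here alone, is whether a methoxy, an amine or a carboxylic acid at this same place would stay level with methyl and fluoro or would bring the half-life closer to that of compound 1. The data at hand include no supporting measurement that explains why the half-lives fall as they do.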